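A few compounds are considered here, and "the series" means these few. Any claim that something is new, unique, unknown or untested is made for them only; others in the source may bear on it.

Measured in an assay for inhibition of histone acetyltransferase KAT2B (Homo sapiens), read by TR-FRET, with a stated time of 10 min, tested at 50 uM; on this read-out lower numbers stand for less inhibition and higher numbers for more inhibition at the one concentration tested (going by the name of the read-out):
compound 1 `O=C(O)CCCCCN1C(=O)/C(=C2/C(=O)Nc3ccccc32)SC1=S` gives 9%
compound 2 `O=C(O)CCCCCN1C(=O)/C(=C2/C(=O)N(Cc3ccccc3)c3ccccc32)SC1=S` gives 13%
compound 3 `CCN1C(=O)/C(=C2\SC(=S)N(CCCCCC(=O)O)C2=O)c2ccccc21` gives 6%

Compound 2 holds the highest of the three numbers, yet its separation from compound 1 is a number 4 percentage points higher from compound 1 to compound 2 (within the scatter) and from compound 3 is a number 7 percentage points lower from compound 2 to compound 3 (within the scatter), both within the scatter, so the three measured compounds cannot be told apart on this read-out. The unmeasured compound 4 `O=C(O)c1ccc(N2C(=O)/C(=C3/C(=O)N(Cc4ccccc4)c4ccccc43)SC2=S)cc1` differs from compound 2 in one place: 4-carboxyphenyl in place of 5-carboxypentyl on an amide-type nitrogen in a ring. Going by the values given here, none of the measured steps touches the nitrogen named in that change; the known steps, a number 4 percentage points higher from compound 1 to compound 2 (within the scatter), a number 3 percentage points lower from compound 1 to compound 3 (within the scatter) and a number 7 percentage points lower from compound 2 to compound 3 (within the scatter), alter the other ring nitrogen or the carbon bound to it, and all stay within the scatter. They give no direct guidance on the change from compound 2 to compound 4, and the flat picture across the measured compounds suggests that no step beyond the scatter should be expected. Compound 4 is estimated at 13%, with a range from 0% to 30%, which means an expected step of no change at the digits printed from compound 2 to compound 4 (within the scatter) in this assay.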

Compound 4, a percentage reported as inhibition, at one concentration (the size of the read-out at that concentration, not a potency): 14%
The estimate for compound 4 lay 1 percentage points below the measured number; low and high end bracket the measured number.
By their numbers in this assay, from the lowest: compounds 3, 1, 2 and 4 (each within the scatter of the next).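

Going by these compounds alone, the nitrogen bearing the carboxylic acid group had stayed unchanged in the earlier compounds, and in this assay replacing 5-carboxypentyl with 4-carboxyphenyl on this amide-type nitrogen gives a number 1 percentage points higher from compound 2 to compound 4 (within the scatter) as the first step read at this position. An open chain can thus give way to a six-membered aromatic ring of carbon only, with the carboxylic acid kept, without a step beyond the scatter. Nothing given here accounts for this result.

Every compound shown carries a carboxylic acid on this nitrogen, leaving open what an amine, a methyl ester or a plain alkyl chain would give there. Also open, on these data alone, is whether any group at this position would give a step beyond the scatter in this assay at all.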